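Isopropyl for methyl on a long-chain amino alcohol

The compounds below may be only part of what the source reports. "The series", "measured", "known", "first", "only" and "open" are said of these compounds alone.

Measured compounds:
compound 1, `CCCCCCCCCCCCCCC[C@@H](O)[C@H](C)N` — 2300 nM
compound 2, `CCCCCCCCC[C@@H](O)[C@@H](N)[C@@H](C)O` — 13000 nM
compound 3, `CCCCCCCCC[C@@H](O)[C@@H](N)[C@@H](C)CC` — 13000 nM

The three measured compounds were tested in a functional assay on HBL-100 cells (Homo sapiens) for antiproliferative activity, read by sulforhodamine B assay, with a stated time of 48 h; on this read-out lower numbers stand for stronger inhibition of growth and higher numbers for weaker inhibition of growth. Compound 1 gives the lowest of the three numbers, and its distance to compound 2 and to compound 3 lies beyond the scatter in both cases. Going by the values given here, compound 2 and compound 3 sit at the same number; their one-place step, no change at the digits printed from compound 2 to compound 3 (within the scatter), is the only measured step and concerns a different position from the one changed here.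

The unmeasured compound 4, `CCCCCCCCCCCCCCC[C@@H](O)[C@@H](N)C(C)C`, differs from compound 1 in one place: isopropyl in place of methyl on a saturated chain carbon bound to an amine nitrogen and a saturated chain carbon. Among the compounds with values here, no measured step touches this position, so the only guidance is the indifference of this assay to the step from compound 2 to compound 3. Compound 4 is therefore expected to stay close to compound 1, with a step of a 1.1-fold higher number from compound 1 to compound 4 (0.04 log units; within the scatter) that does not exceed the scatter. The estimate for compound 4 is 2500 nM, expected to fall between 1000 nM and 6500 nM.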

Compound 4, concentration for 50% growth inhibition: 4900 nM
Estimate against measurement, compound 4: 2.0-fold (0.29 log units) below, and the stated range covers the measured number.
By their numbers in this assay, from the lowest: compound 1; then compound 4; then compounds 2 and 3 (each within the scatter of the next).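

In this assay, the carbon bound to an amine nitrogen and a saturated chain carbon responds to the exchange of methyl for isopropyl, which gives a 2.1-fold higher number from compound 1 to compound 4 (0.33 log units; beyond the scatter). Going by these compounds alone, the only earlier step, no change at the digits printed from compound 2 to compound 3 (within the scatter), concerned another position, so this is the first measured sign that the present position is not indifferent to the group it carries, although the loss is modest. Nothing shown here offers an explanation for this step.

As far as these compounds go, it remains open whether the number changes gradually with the group at this place, as an ethyl or a tert-butyl group there would show. Also open, from the compounds shown here alone, is whether isopropyl in place of methyl gives a similar step on the shorter chain carried by compound 2 and compound 3.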